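A few compounds are considered here, and "the series" means these few. Any claim that something is new, unique, unknown or untested is made for them only; others in the source may bear on it.

Measured in a functional assay on MDA-MB-231 cells (Homo sapiens) for cytotoxicity, read by MTT assay, with a stated time of 72 h; on this read-out lower numbers stand for stronger inhibition and higher numbers for weaker inhibition:
compound 1 `CN(C)Cc1ccc2nc(NC(=O)N/N=C/c3cn(Cc4ccc(Cl)cc4)c4ccccc34)sc2c1` gives 880 nM;
compound 2 `CCN(CC)Cc1ccc2nc(NC(=O)N/N=C/c3cn(Cc4ccccc4)c4ccccc34)sc2c1` gives 1470 nM;
compound 3 `CN(C)Cc1ccc2nc(NC(=O)N/N=C/c3cn(Cc4ccc(Cl)cc4Cl)c4ccccc34)sc2c1` gives 1410 nM.

Compound 4 `CCN(CC)Cc1ccc2nc(NC(=O)N/N=C/c3cn(Cc4ccccc4Cl)c4ccccc34)sc2c1` is still to be measured in this assay. Compound 2 and compound 1 differ in more than one place; the difference between the two cores is not broken down here. All three measured values lie within the usual scatter of one another.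

One change has a measured precedent. From compound 1 to compound 3 it is chloro in place of hydrogen on an aromatic carbon, and it gave a 1.6-fold higher number from compound 1 to compound 3 (0.20 log units; within the scatter). From compound 2 to compound 4 it is chloro in place of hydrogen on an aromatic carbon. The surroundings are not identical: in compound 3 the entering chloro stands ortho to a large group and meta to a chloro group, while in compound 4 it stands ortho to a large group only. It is therefore the same kind of change, not the same change.

For the measured compounds named here, the step from compound 2 to compound 4 is expected to be a 1.6-fold higher number from compound 2 to compound 4 (0.19 log units; within the scatter), of about the size seen in a 1.6-fold higher number from compound 1 to compound 3 (0.20 log units; within the scatter), because compound 2 starts from 1470 nM and the only precedent is a small step. Compound 4 is expected to give 2300 nM, with a range from 1000 nM to 5500 nM.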

Compound 4, half-maximal inhibitory concentration: 900 nM
For compound 4 the middle estimate is 2.6-fold (0.41 log units) above the measured one, and the stated range ends above it.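

In this assay the change from benzyl to 2-chlorobenzyl gives a 1.6-fold lower number from compound 2 to compound 4 (0.21 log units; within the scatter) and so adds a second small step for this kind of change. Set beside the earlier step, the new one does not differ from it beyond what two such steps can show: the same change on two cores in this assay, a 1.6-fold higher number (0.20 log units; within the scatter) from compound 1 to compound 3 and a 1.6-fold lower number (0.21 log units; within the scatter) from compound 2 to compound 4, 2.6-fold (0.42 log units) apart, within the scatter of two such steps. On these two pairs the change leaves the number within the scatter on both cores, but this does not show that its effect is the same on each core or that it would carry to a further core, as the opposite directions of the two small steps cannot be read as a real difference and the entering chloro has different surroundings in the two pairs.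

Still open, as far as these compounds go, is whether a fluoro, a methoxy or a nitrile in the same place on the aromatic ring would give a step beyond the scatter. Also open, from the compounds shown here alone, is how a longer chain on the amine nitrogen, or a cyclic amine in its place, would read in this assay.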